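A few compounds are considered here, and "the series" means these few. Any claim that something is new, unique, unknown or untested is made for them only; others in the source may bear on it.

Measured compounds:
Compound 1, `CCCS(=O)(=O)N1CCC(CNC(=O)c2c(F)ccc(Cl)c2F)(C(=O)N2CCOCC2)CC1`, gives 10000 ug/mL.
Compound 2, `CCCS(=O)(=O)N1CCC(CNC(=O)C2CC2)(C(=O)N2CCOCC2)CC1`, gives 10000 ug/mL.

Both values were obtained in a physicochemical assay for solubility; on this read-out lower numbers stand for lower solubility and higher numbers for higher solubility. Compound 2 stands level with compound 1 at the digits shown; the step from compound 1 to compound 2, a cyclopropyl in place of 3-chloro-2,6-difluorophenyl on a carbonyl carbon, read no change at the digits printed from compound 1 to compound 2 (within the scatter).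

Compound 3, `CCCS(=O)(=O)N1CCC(CNC(=O)c2ccccc2OC(F)(F)F)(C(=O)N2CCOCC2)CC1`, has not yet been measured. It differs from compound 2 in one place: 2-(trifluoromethoxy)phenyl in place of cyclopropyl on a carbonyl carbon.

Going by the values given here, only the single step from compound 1 to compound 2 bears on this change. There an aromatic ring was exchanged for the cyclopropyl without any movement in this assay, and compound 3 returns an aromatic ring to the same carbonyl carbon. Compound 3 is therefore expected to show no change at the digits printed from compound 2 to compound 3 (within the scatter), that is, no step beyond the scatter. Compound 3 is estimated at 10000 ug/mL, within a range from 5000 ug/mL to 10000 ug/mL.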

Compound 3, solubility: 10000 ug/mL
Compound 3: the middle estimate sits on the measured number at the digits printed; the measured number falls inside the stated range.
By their numbers in this assay, from the lowest: compounds 1, 2 and 3 (each within the scatter of the next).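

In this assay the same carbonyl carbon now carries a third group, and the read-out shows no change at the digits printed from compound 2 to compound 3 (within the scatter) and also no change at the digits printed from compound 1 to compound 3 (within the scatter). The entering 2-(trifluoromethoxy)phenyl has 11 heavy atoms, including oxygen and fluorine, and 1 hydrogen-bond acceptor, against 3 heavy atoms and no acceptor for the cyclopropyl, so this position has now taken a larger change in both ring type and atom count with no step beyond the scatter, and two differently substituted aromatic groups read level. No measurement shown here gives a reason for this flat read-out.

Going by these compounds, whether an amine or a carboxylic acid on this carbonyl carbon would move the read-out in this assay stays open. So does the effect of replacing the propyl chain or the morpholine of the shared core.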